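Hydroxyethyl in place of butyl on the shared core

The source may hold more compounds than are shown below. What is called first, only, known or untested is meant among the compounds shown, and "the series" means these compounds.

Compound 1 `Fc1ccccc1Cn1nnc2c(NC3CCCCC3)nc(-c3ccccc3)nc21` gives 1150000 nM in an assay on isolated protein for binding affinity to adenosine receptor A1 (Bos taurus); on this read-out lower numbers stand for stronger inhibition and higher numbers for weaker inhibition.
Compound 2 `CCCCNc1nc(-c2ccccc2)nc2c1nnn2Cc1ccccc1F` gives 4300000 nM in this assay.

Of the two measured numbers, compound 2 shows the higher one, with a 3.7-fold higher number from compound 1 to compound 2 (0.57 log units; beyond the scatter) standing between them. Compound 3 `OCCNc1nc(-c2ccccc2)nc2c1nnn2Cc1ccccc1F` differs from compound 2 by hydroxy in place of ethyl on a saturated chain carbon, two bonds along the chain from a nitrogen on an aromatic ring. Among the measured compounds shown here, no measured step covers a change of this kind; the only known step, butyl in place of cyclohexyl, was modest, showing that the group on this nitrogen does move the number but giving no direction for hydroxy in place of ethyl. With little to go on, compound 3 is expected near its neighbour, estimated at 5000000 nM (range 1500000 nM to 20000000 nM), a step of a 1.2-fold higher number from compound 2 to compound 3 (0.07 log units; within the scatter).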

Compound 3, inhibition constant: 54000000 nM
For compound 3 the middle estimate is 11-fold (1.03 log units) below the measured one, outside the stated range (above it).
By their numbers in this assay, from the lowest: compound 1; then compound 2; then compound 3.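

In this assay, hydroxy in place of ethyl on the chain gives a 13-fold higher number from compound 2 to compound 3 (1.10 log units; beyond the scatter), so a change at the far end of this chain can matter a great deal. Against the starting group, 2-hydroxyethyl in place of cyclohexyl gives a 47-fold higher number from compound 1 to compound 3 (1.67 log units; beyond the scatter), and the number rises along the series from cyclohexyl through butyl to 2-hydroxyethyl. No measurement available here accounts for the size of these steps. As far as these compounds go, whether an amine or a methoxy group at the chain end would give a similar rise remains open, as does the effect of a longer chain ending in hydroxy.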